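The source may report more compounds than this note shows. Statements on the series, on what has been measured and on what is new or still open speak of the compounds shown alone.

Compound 1 `Cc1ccc(-c2nc(CNc3ccc(C(=O)NO)cc3)n(-c3ccccc3)n2)cc1`: 224 nM
Compound 2 `O=C(NO)c1ccc(NCc2nc(-c3ccc(Cl)cc3)nn2-c2ccccc2)cc1`: 181 nM
Compound 3 `Cc1ccc(-c2nc(CNc3ccc(C(=O)NO)cc3)n(-c3ccccc3)n2)s1`: 30.6 nM

In an assay on Sf9 cells for inhibition of protein deacetylase HDAC6 (Homo sapiens), read by fluorescence, with a stated time of 40 min (on this read-out lower numbers stand for stronger inhibition and higher numbers for weaker inhibition), compound 3 stands lowest of the three, and its steps to both others lie beyond the scatter: a 7.3-fold lower number from compound 1 to compound 3 (0.86 log units; beyond the scatter) and a 5.9-fold lower number from compound 2 to compound 3 (0.77 log units; beyond the scatter). Compound 4 `O=C(NO)c1ccc(NCc2nc(-c3ccccc3Cl)nn2-c2ccccc2)cc1` has not yet been measured; it differs from compound 3 by 2-chlorophenyl in place of 5-methylthiophen-2-yl on an aromatic carbon. This largely undoes what set compound 3 apart, since the two steps just named both show that bringing in the 5-methylthiophen-2-yl group in place of a chlorophenyl or methylphenyl group lowered the number modestly, while a 1.2-fold lower number from compound 1 to compound 2 (0.09 log units; within the scatter) shows that swapping chloro for methyl hardly mattered. A modest step back to a higher number is therefore expected, a 5.6-fold higher number from compound 3 to compound 4 (0.74 log units; beyond the scatter). Compound 4 is estimated at 170 nM, with a likely range from 60 nM to 500 nM.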

Compound 4, half-maximal inhibitory concentration: 185 nM
The estimate for compound 4 lay 1.1-fold (0.04 log units) below the measured number; the range from low to high includes it.
By their numbers in this assay, from the lowest: compound 3; then compounds 2, 4 and 1 (each within the scatter of the next).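

In this assay the change from 4-chlorophenyl to 2-chlorophenyl gives a 1.0-fold higher number from compound 2 to compound 4 (0.01 log units; within the scatter) and the change from 4-methylphenyl to 2-chlorophenyl gives a 1.2-fold lower number from compound 1 to compound 4 (0.08 log units; within the scatter) so compounds 1, 2 and 4, which all carry a six-membered aromatic ring here, lie within the scatter of one another. Only the 5-methylthiophen-2-yl group stands apart among these four, and the change away from it gives a 6.0-fold higher number from compound 3 to compound 4 (0.78 log units; beyond the scatter) even with the chloro group in a different ring position. Nothing measured here explains this difference. Going by these compounds, it remains open whether the lower number needs the methyl group on the thiophene, or whether a thiophen-2-yl group without it, or one carrying chloro or an amine instead, would give a similar number.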